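The source may hold more compounds than are shown below. What is called first, only, known or untested is meant among the compounds shown, and "the series" means these compounds.

Compound 1 `O=C(Nc1cccc(-c2oc3cc(-c4ccc(F)cc4)ccc3c(=O)c2O)c1)c1ccccc1F`: 7570 nM
Compound 2 `O=C(Nc1cccc(-c2oc3cc(-c4ccc(F)cc4)ccc3c(=O)c2O)c1)c1ccc(F)cc1`: 8590 nM

In a functional assay on MCF7 cells (Homo sapiens) for antiproliferative activity, read by CCK-8 assay, with a stated time of 72 h (on this read-out lower numbers stand for stronger inhibition and higher numbers for weaker inhibition), compound 1 has the lowest of the two numbers shown, but compound 2 sits within the scatter of it: a 1.1-fold higher number from compound 1 to compound 2 (0.05 log units; within the scatter). Compound 3 `O=C(Nc1cccc(-c2oc3cc(-c4ccc(F)cc4)ccc3c(=O)c2O)c1)c1ccc(C(F)(F)F)cc1` differs from compound 1 by 4-(trifluoromethyl)phenyl in place of 2-fluorophenyl on a carbonyl carbon. Among the compounds with values here, the only measured step that bears on this, a 1.1-fold higher number from compound 1 to compound 2 (0.05 log units; within the scatter), also exchanges the ring on the carbonyl carbon and changed nothing beyond the scatter, so a similar outcome is expected here. Compound 3 is therefore estimated at 9000 nM, a step of a 1.2-fold higher number from compound 1 to compound 3 (0.08 log units; within the scatter), with a range from 4500 nM to 18000 nM.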

Compound 3, half-maximal inhibitory concentration: 32600 nM
The estimate for compound 3 lay 3.6-fold (0.56 log units) below the measured number; measured number outside the range, above it.
By their numbers in this assay, from the lowest: compounds 1 and 2 (each within the scatter of the next); then compound 3.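

The ring on the carbonyl carbon does not tolerate every exchange: moving to 4-(trifluoromethyl)phenyl weakens inhibition modestly (a 4.3-fold higher number from compound 1 to compound 3 (0.63 log units; beyond the scatter)). The narrowest comparison, trifluoromethyl in place of fluoro on an aromatic carbon, shows a similar loss (a 3.8-fold higher number from compound 2 to compound 3 (0.58 log units; beyond the scatter)), so the group carried by this ring can matter even though the earlier exchange made no clear difference. No measurement shown here explains the loss. Going by these compounds, whether a plain phenyl ring would differ from these remains open. So does the effect of a methoxy group, an amine or a carboxylic acid on this ring.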